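Shortening the Hydroxamate Linker Across Two Cores

The source may hold more compounds than are shown below. What is called first, only, known or untested is meant among the compounds shown, and "the series" means these compounds.

Measured compounds:
- Compound 1, `Nc1ncnc2c1c(-c1cnc3[nH]ccc3c1)nn2CCCCCCC(=O)NO`, in a functional assay on MCF7 cells (Homo sapiens) for inhibition, read by MTT assay, with a stated time of 72 h (on this read-out higher numbers stand for weaker inhibition and lower numbers for stronger inhibition), gives 19800 nM.
- Compound 2, `Nc1ncnc2c1c(-c1cnc3[nH]ccc3c1)nn2CCC(=O)NO`, reaches only a limit in this assay, > 150000 nM.
- Compound 3, `Nc1nc2cc(-c3nn(CCCCCC(=O)NO)c4ncnc(N)c34)ccc2o1`, in this assay gives 12400 nM.

Compound 1 and compound 2 share a core and differ by one change, (hydroxycarbamoyl in place of 4-(hydroxycarbamoyl)butyl on a saturated chain carbon, two bonds along the chain from an aromatic nitrogen). That change produced an at least 7.5-fold higher number from compound 1 to compound 2 (0.87 log units; beyond the scatter), a step whose size is bounded by the limit of > 150000 nM in this assay, at which 1 of the 3 values shown sits. Compound 3 carries a different core; the difference between the two cores is not broken down here. Its value sits near that of compound 1, within the usual scatter, so no order between them is claimed.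

Compound 4, `Nc1nc2cc(-c3nn(CC(=O)NO)c4ncnc(N)c34)ccc2o1`, has not yet been tested. It differs from compound 3 by hydroxycarbamoyl in place of 4-(hydroxycarbamoyl)butyl on a saturated chain carbon bound to an aromatic nitrogen. This is the same kind of change as that from compound 1 to compound 2, though the place differs: there the group sat two bonds along the chain from an aromatic nitrogen, here it is bound directly to the aromatic nitrogen. Resting on an at least 7.5-fold higher number from compound 1 to compound 2 (0.87 log units; beyond the scatter), compound 4 is expected to show a 12-fold higher number from compound 3 to compound 4 (1.08 log units; beyond the scatter), most likely again reaching a limit. Compound 4 is estimated at 150000 nM, between 50000 nM and 450000 nM.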

Compound 4, half-maximal inhibitory concentration: > 100000 nM
Compound 4: only a limit was reported (the forecaster's own chance of this, stated with the estimate: 65%); the middle value lies beyond the limit too.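

Compound 4 reaches only a limit in this assay, > 100000 nM. On this second core, the same change gives an at least 8.0-fold higher number from compound 3 to compound 4 (0.90 log units; beyond the scatter), and it therefore moves the number in the same direction on both cores: the same change on two cores in this assay, an at least 7.5-fold higher number (0.87 log units; beyond the scatter) from compound 1 to compound 2 and an at least 8.0-fold higher number (0.90 log units; beyond the scatter) from compound 3 to compound 4; the limit leaves it open whether they differ. This shows that the loss carries over from one core to the other in these two pairs, but it does not give the true size of the loss on either core, and it does not show that the two cores respond equally, since the place of the change also differs.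

The compounds shown leave open how a chain longer than those of compound 1 and compound 3 would read on either core, and at which chain length of intermediate size the number starts to climb. They also leave open whether a carboxylic acid at the chain end could stand in for the hydroxycarbamoyl group on these cores.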